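Swapping bromine for tert-butyl on a shared core

This account rests on a few compounds, and the source may have more. Where it says the series, first, only, none or still open, it means among the compounds named here.

Compound 1 `Cc1ccc(Cn2cc(COc3ccc4c(=O)ccoc4c3)nn2)cc1` in a functional assay on SGC-7901 cells (Homo sapiens) for cytotoxicity, read by MTT assay, with a stated time of 48 h (a lower number here means a stronger inhibitor, a higher number a weaker inhibitor), gives > 100000 nM.
Compound 2 `O=c1ccoc2cc(OCc3cn(Cc4ccc(F)cc4)nn3)ccc12` gives > 100000 nM.
Compound 3 `O=c1ccoc2cc(OCc3cn(Cc4ccc(Br)cc4)nn3)ccc12` gives > 100000 nM.

The value of compound 3 is a limit of the assay, not a number. Compound 3 thus rests at the limit of > 100000 nM in this assay, at which 3 of the 3 values shown sit, where compound 1 and compound 2 rest as well. Compound 4 `CC(C)(C)c1ccc(Cn2cc(COc3ccc4c(=O)ccoc4c3)nn2)cc1` differs from it by tert-butyl in place of bromo on an aromatic carbon. The measured steps a step that the two limits leave unreadable from compound 1 to compound 2, a step that the two limits leave unreadable from compound 1 to compound 3 and a step that the two limits leave unreadable from compound 2 to compound 3 all concern swaps at this same position, yet none of them can be sized, since both ends sit at the limit. Among the measured compounds shown here, no measured step therefore points to a gain or loss beyond the scatter for compound 4. Compound 4 is expected to give 100000 nM, within 40000 nM to 300000 nM, most likely again as a limit. The step from compound 3 is estimated as a number no higher from compound 3 to compound 4 (the limit leaves the size open).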

Compound 4, half-maximal inhibitory concentration: > 100000 nM
Compound 4 ended at the assay's limit (the forecaster's own chance of this, stated with the estimate: 85%); the middle value lies on the limit itself.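

No step between compound 4 and compound 1, compound 2 or compound 3 can be read, as all four stand at a limit rather than a number: the limit of > 100000 nM in this assay, at which 4 of the 4 values shown sit.

The compounds shown leave open how strong each one really is in this assay, and whether the group swapped at this position matters at all.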